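From thiophen-3-yl to thiophen-2-yl on a carbonyl carbon

The source may hold more compounds than are shown below. What is called first, only, known or untested is meant among the compounds shown, and "the series" means these compounds.

Measured in a functional assay on BXPC-3 cells (Homo sapiens) for antiproliferative activity, read by sulforhodamine B assay, with a stated time of 72 h; a higher number here means a weaker inhibitor, a lower number a stronger inhibitor:
- compound 1 `CC(C)(C)c1[nH]cnc1/C=c1\[nH]c(=O)/c(=C/c2cccc(C(=O)N3CCCC3)c2)[nH]c1=O`: 325 nM
- compound 2 `CC(C)(C)c1[nH]cnc1/C=c1\[nH]c(=O)/c(=C/c2cccc(C(=O)c3ccncc3)c2)[nH]c1=O`: 23.8 nM
- compound 3 `CC(C)(C)c1[nH]cnc1/C=c1\[nH]c(=O)/c(=C/c2cccc(C(=O)c3ccsc3)c2)[nH]c1=O`: 1.56 nM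

Compound 3 has the lowest number of the three. Compound 4 `CC(C)(C)c1[nH]cnc1/C=c1\[nH]c(=O)/c(=C/c2cccc(C(=O)c3cccs3)c2)[nH]c1=O` carries thiophen-2-yl in place of thiophen-3-yl on a carbonyl carbon. The two have the same atoms, joined differently. Two large measured steps exchange the group on that carbonyl carbon: a 210-fold lower number from compound 1 to compound 3 (2.32 log units; beyond the scatter) and a 15-fold lower number from compound 2 to compound 3 (1.18 log units; beyond the scatter). Both lie beyond the scatter, but neither compares two thiophenes, so they only loosely guide this swap. In this assay, a far smaller change is expected, at most a slight rise in the number and probably none beyond the scatter. The estimated step is a 1.6-fold higher number from compound 3 to compound 4 (0.20 log units; within the scatter). For compound 4 the estimate is 2.5 nM, with an expected range of 1 nM to 7 nM.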

Compound 4, half-maximal inhibitory concentration in the BXPC-3 assay: 1.72 nM
The estimate for compound 4 lay 1.5-fold (0.16 log units) above the measured number, and the stated range covers the measured number.
By their numbers in the BXPC-3 assay, from the lowest: compounds 3 and 4 (each within the scatter of the next); then compound 2; then compound 1.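

In the BXPC-3 assay the two thiophene attachments cannot be told apart: a 1.1-fold higher number from compound 3 to compound 4 (0.04 log units; within the scatter). Among these compounds, in the BXPC-3 assay, thiophen-2-yl stands well clear of the other two groups, with a 14-fold lower number from compound 2 to compound 4 (1.14 log units; beyond the scatter) and a 190-fold lower number from compound 1 to compound 4 (2.28 log units; beyond the scatter), so on this carbonyl carbon either thiophene attachment serves, which the earlier comparisons of unlike groups could not show. In a physicochemical assay for solubility, read by HPLC, with a stated time of 24 h (a lower number here means a less soluble compound, a higher number a more soluble compound), compound 3 gives < 0.1 ug/mL, which is a limit of the assay. In the physicochemical assay compound 4 gives < 0.1 ug/mL, which is also a limit of the assay. In the physicochemical assay the step between compound 3 and compound 4 cannot be read, as both values are limits: the limit of < 0.1 ug/mL in the physicochemical assay, at which 2 of the 2 values shown sit.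

Still open, from the compounds shown here alone, is whether a furan-2-yl or a phenyl on the carbonyl carbon would match the two thiophenes in the BXPC-3 assay. Also open, going by these compounds, is whether an amine on the thiophene would bring a reading off that limit in the physicochemical assay.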